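This account rests on a few compounds, and the source may have more. Where it says the series, first, only, none or still open, it means among the compounds named here.

The study concerns compound 1 `COc1ccc(-c2cc(=O)c3c(OC)cc(OC)cc3[nH]2)cc1` and two relatives that carry a sulfonyl group on the aromatic nitrogen, all tested in a functional assay on HepG2 cells (Homo sapiens) for antiproliferative activity, with a stated time of 72 h; a higher number here means that more compound is needed for the effect, a lower number that less compound is needed. Compound 1 reaches only a limit of this assay, giving > 31100 nM, which is the limit of > 31100 nM in this assay, at which 1 of the 3 values shown sits. Compound 2 `COc1ccc(-c2cc(=O)c3c(OC)cc(OC)cc3n2S(=O)(=O)c2c(F)c(F)c(F)c(F)c2F)cc1` likewise reaches only a limit, with > 34400 nM. Compound 3 `COc1ccc(-c2cc(=O)c3c(OC)cc(OC)cc3n2S(=O)(=O)c2ccc(Cl)cc2)cc1` also stops at a limit, giving > 34400 nM, which is the limit of > 34400 nM in this assay, at which 2 of the 3 values shown sit. Neither comparison among the measured compounds can be read as a step: a step that the two limits leave unreadable from compound 1 to compound 3 and a step that the two limits leave unreadable from compound 2 to compound 3 both fall between limits. Compound 4 `COc1ccc(-c2cc(=O)c3c(OC)cc(OC)cc3n2S(=O)(=O)c2ccc(OC)cc2)cc1` differs from compound 1 by (4-methoxyphenyl)sulfonyl in place of hydrogen on an aromatic nitrogen. The measured steps that bear on this change are the two unreadable ones just named, so no size or direction can be expected beyond the scatter, and compound 4 is most likely to sit once more at a limit. For compound 4 the estimated value in this assay is 45000 nM, within a range of 15000 nM to 150000 nM. The expected step is therefore a step that the limit leaves unreadable from compound 1 to compound 4.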

Compound 4, half-maximal effective concentration: > 82700 nM
Compound 4: only a limit was reported; the forecaster's own chance of this, stated with the estimate: 85%; middle value at least 1.8-fold (0.26 log units) from the limit.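

In this assay compound 4 gives > 82700 nM, which is a limit. Within the data shown here, no step to compound 4 from compound 1, compound 2 or compound 3 can be read, as all four results are limits. The compounds shown leave open what concentration any of them would need for the effect, and whether a sulfonyl group on the aromatic nitrogen changes it.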